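The source may report more compounds than this note shows. Statements on the series, on what has been measured and on what is new or still open speak of the compounds shown alone.

Measured so far in an ADME assay on BCBL1 cells (Homo sapiens) for cytotoxicity, with a stated time of 7 days; a higher number here means that more compound is tolerated, a lower number that less compound is tolerated:

Compound 1 `CC(C)CSc1nc(N)nc2c1ncn2/C=C1/CC1(CO)CO`: > 20000 nM, a limit.
Compound 2 `C=CCOc1nc(N)nc2c1ncn2/C=C1/CC1(CO)CO`: > 20000 nM, a limit.

Among the measured compounds shown here, compound 2 therefore has no numerical value, and the one other measurement available for comparison is also only a limit. Both measured compounds sit at the limit of > 20000 nM in this assay, at which 2 of the 2 values shown sit.

Compound 3 `CCOc1nc(N)nc2c1ncn2/C=C1/CC1(CO)CO` differs from compound 2 by methyl in place of vinyl on a saturated chain carbon bound to an oxygen on an aromatic ring. Read one bond further out, this is allyloxy to ethoxy, with the rest of the structure unchanged.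

For the measured compounds named here, the only measured step that bears on this change is a step that the two limits leave unreadable from compound 1 to compound 2. It replaces a different group at the same aromatic carbon, but it gives no size or direction to carry forward. On the evidence of compound 1 and compound 2, no step beyond the scatter is expected in this assay, and no direction can be assigned. The expected step is a step that the limit leaves unreadable from compound 2 to compound 3. Compound 3 is most likely to be reported as a limit again. For compound 3 the estimated value is 25000 nM, with an expected range of 12000 nM to 60000 nM.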

Compound 3, half-maximal cytotoxic concentration: > 20000 nM
Compound 3: only a limit was reported; the forecaster's own chance of this, stated with the estimate: 85%; the middle value lies beyond the limit too.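

In this assay compound 3 gives > 20000 nM as a limit. Among the compounds shown here, no step among compound 1, compound 2 and compound 3 can be read, and all three share one limit: the limit of > 20000 nM in this assay, at which 3 of the 3 values shown sit. The compounds shown leave open where the true cytotoxic concentrations lie and whether isobutylsulfanyl, allyloxy and ethoxy differ at all in this read-out.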